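A few compounds are considered here, and "the series" means these few. Any claim that something is new, unique, unknown or untested is made for them only; others in the source may bear on it.

Three compounds of the series have so far been run in a physicochemical assay for lipophilicity, at pH 7.4; on this read-out higher numbers stand for higher lipophilicity and lower numbers for lower lipophilicity. Compound 1 `Cc1nc(C)c(-c2nnc(-c3ccc(OC(C)C)c(Cl)c3)s2)s1` gives 7.76 in this assay, compound 2 `Cc1c(-c2noc(-c3ccc(OC(C)C)c(C#N)c3)n2)ccc2c1CCN(CCC(=O)O)C2` gives 3.41, and compound 3 `Cc1nn(-c2nnc(-c3ccc(OC(C)C)c(Cl)c3)s2)c(C)c1CCC(=O)O` gives 4.3. Among these three numbers compound 3 stands second highest: its nearest neighbour is compound 2, which lies lower by a gap beyond the usual scatter, and its furthest is compound 1, which lies higher by a gap far beyond the scatter.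

Compound 4 `Cc1nn(-c2nnc(-c3ccc(OC(C)C)c(Cl)c3)s2)c(C)c1CC(=O)O` has not yet been measured in this assay. It differs from compound 3 in a single place, carboxy in place of carboxymethyl on a saturated chain carbon bound to an aromatic carbon. For the measured compounds named here, no measured pair in the set shows this change, so the size of the step cannot be read from existing data. A small downward step in this assay is expected, roughly the size of the usual scatter, as given by a number 0.40 log units lower from compound 3 to compound 4 (beyond the scatter). Compound 4 is accordingly expected to give about 3.9 in this assay, within a range from 3.4 to 4.4.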

Compound 4, distribution coefficient: 3.62
For compound 4 the middle estimate is 0.28 log units above the measured one, within the range that was stated.
By their numbers in this assay, from the lowest: compounds 2 and 4 (each within the scatter of the next); then compound 3; then compound 1.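

Working from the shared core, shortening 2-carboxyethyl to carboxymethyl gives the first direct reading at this place in this assay and yields a number 0.68 log units lower from compound 3 to compound 4 (beyond the scatter) as a modest step. The counted hydrogen-bond donors and acceptors are the same in the group that leaves and the group that enters, so this step at a saturated chain carbon bound to an aromatic carbon comes with a change of chain length and no change in those counts. No measurement on hand accounts for the size of this step.

From the compounds shown here alone, with a single step at this place, the direction for a longer chain carrying the carboxylic acid remains open. Also open, going by these compounds, is how an amine or a primary amide in place of the carboxylic acid would read on the same chain.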